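Amide aryl variation on the shared core

This account rests on a few compounds, and the source may have more. Where it says the series, first, only, none or still open, it means among the compounds named here.

Measured compounds:
compound 1, `CN1[C@@H]2c3[nH]c4ccccc4c3C[C@H]1[C@H](C#N)N1[C@@H](CNC(=O)c3ccc(F)cc3)c3[nH]c4ccccc4c3C[C@@H]21`, gives 980 nM in a functional assay on MCF7 cells (Homo sapiens) for cytotoxicity, read by MTT assay, with a stated time of 72 h; on this read-out lower numbers stand for stronger inhibition and higher numbers for weaker inhibition.
compound 2, `CCc1ccc(C(=O)NC[C@H]2c3[nH]c4ccccc4c3C[C@H]3[C@H]4c5[nH]c6ccccc6c5C[C@@H]([C@H](C#N)N23)N4C)cc1`, gives 170 nM in this assay.

Within the data shown here, compound 2 holds the lower of the two numbers; the measured step between the two is a 5.8-fold lower number from compound 1 to compound 2 (0.76 log units; beyond the scatter), which places compound 2 clearly ahead on the two values so far.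

Compound 3, `CN1[C@@H]2c3[nH]c4ccccc4c3C[C@H]1[C@H](C#N)N1[C@@H](CNC(=O)c3ccc4ccccc4c3)c3[nH]c4ccccc4c3C[C@@H]21`, has not yet been measured. It differs from compound 2 by naphthalen-2-yl in place of 4-ethylphenyl on a carbonyl carbon.

Among the measured compounds shown here, only one measured step touches the aryl group on the amide carbonyl: a 5.8-fold lower number from compound 1 to compound 2 (0.76 log units; beyond the scatter). That step shows that exchanging the substituent pattern on this aryl group can move the number beyond the scatter. For the measured compounds named here, no measured pair covers a second fused aromatic ring in this place, so the direction for compound 3 rests on that single step alone and is taken as roughly neutral to slightly favourable.

Compound 3 is therefore expected to give about 150 nM in this assay, with a range from 50 nM to 500 nM. This estimate corresponds to an expected change of a 1.1-fold lower number from compound 2 to compound 3 (0.05 log units; within the scatter), most likely within the scatter of compound 2.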

Compound 3, half-maximal inhibitory concentration: 4650 nM
Beside the measured number, compound 3's estimate is 31-fold (1.49 log units) below it; measured number above the stated range.
By their numbers in this assay, from the lowest: compound 2; then compound 1; then compound 3.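

In this assay, the aryl group on the amide carbonyl can also move the number strongly upward: naphthalen-2-yl in place of 4-ethylphenyl gives a 27-fold higher number from compound 2 to compound 3 (1.44 log units; beyond the scatter), a large step, and naphthalen-2-yl in place of 4-fluorophenyl gives a 4.7-fold higher number from compound 1 to compound 3 (0.68 log units; beyond the scatter), a modest one. The earlier step showed only that ethyl in place of fluoro lowers the number, whereas compound 3 now ranks behind both compounds with a single aromatic ring on the carbonyl carbon, so among these three the second fused ring goes with the highest number and a larger carbon-only aryl group does not extend the gain seen with 4-ethylphenyl. No measurement in hand bears on why this exchange raises the number.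

As far as these compounds go, whether a longer chain, such as propyl or butyl, in place of the ethyl of compound 2 would lower the number further remains open. Also open, from the compounds shown here alone, is how an amine or a carboxylic acid in that place would compare with ethyl and fluoro on the same aryl group.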